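The source may report more compounds than this note shows. Statements on the series, on what has been measured and on what is new or still open speak of the compounds shown alone.

In a functional assay on PC-12 cells (Rattus norvegicus) for cytotoxicity, read by MTT assay, with stated times of 2 h and 24 h, tested at 1 uM (on this read-out higher numbers stand for a stronger effect at the one concentration tested and lower numbers for a weaker effect), compound 2 `Oc1cc(C(F)(F)F)ccc1-c1nc(-c2ccccc2O)n(-c2ccc(OC(F)(F)F)cc2)n1` gives 65.5%, the lowest of the three numbers at hand. Compound 1 `Oc1cc(C(F)(F)F)ccc1-c1nc(-c2ccccc2O)n(-c2ccc(Br)cc2)n1` gives 69.4% in this assay, and compound 3 `Cc1cc(C)cc(-n2nc(-c3ccc(C(F)(F)F)cc3O)nc2-c2ccccc2O)c1` gives 76.9%. The step of a number 3.9 percentage points lower from compound 1 to compound 2 (within the scatter) stays within the scatter, as does a number 7.5 percentage points higher from compound 1 to compound 3 (within the scatter), while a number 11.4 percentage points higher from compound 2 to compound 3 (beyond the scatter) goes beyond it. Compound 4 `Oc1cc(C(F)(F)F)ccc1-c1nc(-c2ccccc2O)n(-c2cc(F)cc(F)c2)n1` differs from compound 2 by 3,5-difluorophenyl in place of 4-(trifluoromethoxy)phenyl on an aromatic nitrogen. For the measured compounds named here, the steps that bear on this change are the two that exchange the group on the aromatic nitrogen, a number 7.5 percentage points higher from compound 1 to compound 3 (within the scatter) and a number 11.4 percentage points higher from compound 2 to compound 3 (beyond the scatter); both point the same way, with only the second beyond the scatter. Compound 4 is therefore expected to sit somewhat above compound 2, with the estimated step of a number 5.5 percentage points higher from compound 2 to compound 4 (within the scatter) likely to be small and possibly no more than the scatter. In this assay compound 4 is estimated at 71%, with a range from 60% to 80%.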

Compound 4, a percentage reported as activity, at one concentration (the size of the read-out at that concentration, not a potency): 75.5%
The estimate for compound 4 lay 4.5 percentage points below the measured number, within the range that was stated.
By their numbers in this assay, from the lowest: compounds 2, 1, 4 and 3 (each within the scatter of the next, the first and the last beyond it).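

In this assay, 3,5-difluorophenyl on the aromatic nitrogen gives a number 1.4 percentage points lower from compound 3 to compound 4 (within the scatter) when it replaces 3,5-dimethylphenyl, so the two 3,5-disubstituted phenyl groups cannot be told apart here. Against the two 4-substituted phenyl groups, the change gives a number 6.1 percentage points higher from compound 1 to compound 4 (within the scatter) from the 4-bromophenyl compound and a number 10 percentage points higher from compound 2 to compound 4 (within the scatter) from the 4-(trifluoromethoxy)phenyl compound, and neither step leaves the scatter, unlike a number 11.4 percentage points higher from compound 2 to compound 3 (beyond the scatter) for the dimethyl analogue. No measurement shown here explains these numbers.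

As far as these compounds go, whether an amine or a carboxylic acid on this phenyl ring, or a longer alkyl chain in its place, would move the read-out beyond the scatter remains open. So does the behaviour of the unsubstituted phenyl group.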